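This account rests on a few compounds, and the source may have more. Where it says the series, first, only, none or still open, it means among the compounds named here.

Of the compounds shown here, three have been tested in a functional assay on KG-1 cells (Homo sapiens) for cytotoxicity, read by luminescence and CellTiter-Glo, with a stated time of 3 days (on this read-out lower numbers stand for stronger inhibition and higher numbers for weaker inhibition), so far. Compound 1, with the structure `N#Cc1cc(Cl)ccc1NC(=O)c1ccc2cccnc2c1O`, gives 3540 nM. Compound 3, built as `N#Cc1ccc(NC(=O)c2ccc3cccnc3c2O)c(Cl)c1`, gives 3670 nM. Compound 2, with the structure `O=C(Nc1ccc(C(F)(F)F)cc1)c1cc(Br)ccc1O`, gives 610 nM, which is the lowest of the three numbers, and its gap to both compound 1 and compound 3 lies beyond the usual scatter, so compound 2 is the strongest inhibitor of the set on these numbers.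

The next compound to be tested, compound 4, has the structure `N#Cc1ccc(NC(=O)c2cc(Br)ccc2O)cc1`. It keeps the core of compound 2 and changes only one group: cyano in place of trifluoromethyl on an aromatic carbon

For the measured compounds named here, no pair of measured compounds differs in just one place, so there is no measured step to lean on here. The change replaces a group of four heavy atoms with one of two heavy atoms and adds a hydrogen-bond acceptor, and nothing in the three measured compounds shows how such a swap plays out on this core. The step from compound 2 to compound 4 is therefore expected to be modest, most likely toward a weaker inhibition, estimated as a 2.5-fold higher number from compound 2 to compound 4 (0.39 log units; beyond the scatter). Compound 4 is accordingly expected to give about 1500 nM, with a range from 500 nM to 4500 nM.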

Compound 4, half-maximal inhibitory concentration: 1290 nM
Compound 4: the middle estimate sits 1.2-fold (0.07 log units) above what was measured; low and high end bracket the measured number.
By their numbers in this assay, from the lowest: compound 2; then compound 4; then compounds 1 and 3 (each within the scatter of the next).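

For the compounds shown here, this is the first pair in the set that differs in only one place, so the group on the aromatic carbon para to a large group can now be read directly: in this assay, cyano in place of trifluoromethyl gives a 2.1-fold higher number from compound 2 to compound 4 (0.33 log units; beyond the scatter). The step is modest but beyond the scatter, so trifluoromethyl has the lower number of the pair, and the exchange of a group of four heavy atoms for one of two heavy atoms, with a hydrogen-bond acceptor added, shifts the number without abolishing the inhibition. Nothing available here explains why the two groups differ in this way.

A single pair gives one step at one position, so it cannot show how other groups at this place would behave, such as an amine, a carboxylic acid, a methoxy group or a longer alkyl chain. It also leaves open whether the same exchange would give a step of similar size and direction on a different core, such as that of compound 1 or compound 3.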